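Half-life notes: 2-hydroxyethyl to (dimethylamino)methyl

The source may hold more compounds than are shown below. What is called first, only, known or untested is meant among the compounds shown, and "the series" means these compounds.

In an ADME assay for pharmacokinetics, read by LC-MS, in phosphate buffer, with a stated time of 120 min, at pH 7.4, tested at 1 uM, in the presence of a further agent that is not named here (on this read-out higher numbers stand for a longer-lived compound and lower numbers for a shorter-lived compound), compound 1 `C=C(Cl)C(=O)Nc1ccccc1` gives 0.05 h. Compound 2 `C=C(C)C(=O)Nc1ccccc1` gives > 8.53 h, which is a limit and not a number. Compound 3 `C=C(CCO)C(=O)Nc1ccccc1` gives > 8.53 h, again only a limit. The series thus meets (the limit of > 8.53 h in this assay, at which 2 of the 3 values shown sit), and compound 3 has no number of its own.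

The next structure is compound 4 `C=C(CN(C)C)C(=O)Nc1ccccc1`, and the change is dimethylamino in place of hydroxymethyl on a saturated chain carbon bound to a double-bonded chain carbon. Among the compounds with values here, the only measured step at that place is a step that the two limits leave unreadable from compound 2 to compound 3, so it offers no size. Exchanges on a double-bonded chain carbon bound to a carbonyl carbon gave an at least 170-fold higher number from compound 1 to compound 2 (2.23 log units; beyond the scatter) and an at least 170-fold higher number from compound 1 to compound 3 (2.23 log units; beyond the scatter). Those steps are large, but they lie at another place and show only that half-life can move widely within this series. Within the data shown here, no measured compound carries dimethylamino, so the expectation is loose. A moderate fall is expected, much smaller than those large steps, with compound 1 at 0.05 h marking how short-lived this series can be. The estimated step is an at least 2.1-fold lower number from compound 3 to compound 4 (0.32 log units; beyond the scatter). For compound 4 the estimated half-life is 4 h, with an expected range of 0.7 h to 12 h.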

Compound 4, half-life: < 0.0334 h
Compound 4 gave a limit, no number; the forecaster's own chance of this, stated with the estimate: 35%; middle value at least 110-fold (2.07 log units) from the limit.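

Within the data shown here, on a saturated chain carbon bound to a double-bonded chain carbon, the only earlier step could not be read, and dimethylamino now gives the first readable size at this place, with an at least 250-fold lower number from compound 3 to compound 4 (2.40 log units; beyond the scatter) and an at least 250-fold lower number from compound 2 to compound 4 (2.40 log units; beyond the scatter). A short half-life in this series is also no longer tied to chloro on a double-bonded chain carbon bound to a carbonyl carbon: (dimethylamino)methyl on that carbon gives an at least 1.4-fold lower number from compound 1 to compound 4 (0.17 log units; that floor lies within the scatter), and since that floor lies within the scatter, no order between the two compounds is claimed here. Compound 4 stands at the short-lived end of this assay, and its value is a limit and not a number: the limit of < 0.0334 h in this assay, at which 1 of the 4 values shown sits.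

On these data alone, with limits at both ends, the true size of these steps remains open, and so does how far compound 4 lies from compound 1. Whether the fall follows amines at this place in general or dimethylamino alone also stays unresolved, and a primary amine, methylamino or methoxy in the same place would separate these readings.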